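Swapping the Fluorophenyl for Bromophenyl on the Shared Core

The source may report more compounds than this note shows. Statements on the series, on what has been measured and on what is new or still open speak of the compounds shown alone.

Compound 1 `COc1cc2c(Oc3ccc(NC(=O)c4nn(-c5ccc(Br)cc5)c(=O)c5ccccc45)cc3F)ccnc2cc1OCCCN1CCCC1` and compound 2 `COc1cc2c(Oc3ccc(NC(=O)c4nn(-c5ccccc5F)c(=O)c5ccccc45)cc3F)ccnc2cc1OCCCN1CCN(C)CC1` share a core and differ at two places. In a functional assay on HT-29 cells (Homo sapiens) for cytotoxicity, read by MTT assay, with a stated time of 72 h (a higher number here means a weaker inhibitor, a lower number a stronger inhibitor), compound 1 gives 670 nM. In this assay compound 2 gives 480 nM. Among the compounds with values here, these two numbers lie within the usual scatter of one another, so compound 2 stands level with compound 1 rather than apart from it, and because the two structures differ in more than one place no single step between them is counted.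

Compound 3 `COc1cc2c(Oc3ccc(NC(=O)c4nn(-c5ccc(Br)cc5)c(=O)c5ccccc45)cc3F)ccnc2cc1OCCCN1CCN(C)CC1` is built from compound 2 by one change: 4-bromophenyl in place of 2-fluorophenyl on an aromatic nitrogen. Compound 1 already carries the 4-bromophenyl group and gives 670 nM. From that, the step from compound 2 to compound 3 is expected to be small, a 1.2-fold higher number from compound 2 to compound 3 (0.07 log units; within the scatter), in no clear direction and not beyond the scatter. Compound 3 is therefore estimated at 560 nM, with a range from 250 nM to 1250 nM.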

Compound 3, half-maximal inhibitory concentration: 850 nM
Beside the measured number, compound 3's estimate is 1.5-fold (0.18 log units) below it, within the range that was stated.
By their numbers in this assay, from the lowest: compounds 2, 1 and 3 (each within the scatter of the next).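

In this assay the swap to 4-bromophenyl in place of 2-fluorophenyl on an aromatic nitrogen can now be read on its own, as a 1.8-fold higher number from compound 2 to compound 3 (0.25 log units; within the scatter) with the rest of the structure unchanged. Compound 3 also isolates 4-methylpiperazin-1-yl in place of pyrrolidin-1-yl on a saturated chain carbon, as a 1.3-fold higher number from compound 1 to compound 3 (0.10 log units; within the scatter) and so neither single change moves the number beyond the scatter, and both positions tolerate either group among these three compounds. Nothing measured here explains this outcome.

The compounds shown leave open whether the reading stays level with an unsubstituted phenyl or a small alkyl group such as methyl on the same nitrogen. They also leave open whether an open-chain amine such as dimethylamino, or a longer chain, would give a number beyond the scatter.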